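A vinyl group replaces acetamidomethyl in compound 1

A few compounds are considered here, and "the series" means these few. Any claim that something is new, unique, unknown or untested is made for them only; others in the source may bear on it.

Compound 1 `COc1ccccc1OCC1SCCN1C(=O)CNC(C)=O` gives 40 mg/kg
Compound 2 `COc1ccc(OCC2SCCN2C(=O)Cn2ccnc2)cc1` gives 48 mg/kg
Compound 3 `COC(=O)c1ccc(OCC2SCCN2C(=O)Cn2ccnc2)cc1` gives 62 mg/kg

These values come from a functional assay on the whole organism for inhibition, with Cavia porcellus as the target (a lower number here means that less compound is needed, a higher number that more compound is needed for the effect), and lie within the scatter of one another, so compound 1 stands level with compound 2 and compound 3. In compound 4 `C=CC(=O)N1CCSC1COc1ccccc1OC` vinyl takes the place of acetamidomethyl on a carbonyl carbon vinyl in place of acetamidomethyl on a carbonyl carbon and the rest of compound 1 is kept. Among the measured compounds shown here, the single measured step, a 1.3-fold higher number from compound 2 to compound 3 (0.11 log units; within the scatter), lies on an aromatic carbon and so bears on this change only indirectly. For the measured compounds named here, no measured step covers the carbonyl carbon, and no shift beyond the scatter is expected in either direction. The expected step is a 1.1-fold higher number from compound 1 to compound 4 (0.05 log units; within the scatter) in this estimate. For compound 4 the estimated value is 45 mg/kg with 18 mg/kg to 110 mg/kg as the expected range.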

Compound 4, dose for half-maximal effect: 74 mg/kg
Compound 4: the middle estimate sits 1.6-fold (0.22 log units) below what was measured; low and high end bracket the measured number.
By their numbers in this assay, from the lowest: compounds 1, 2, 3 and 4 (each within the scatter of the next).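

In this assay, among the compounds shown here, the first measured step on this carbonyl carbon, vinyl in place of acetamidomethyl, gives a 1.9-fold higher number from compound 1 to compound 4 (0.27 log units; within the scatter), so here the shorter group with neither a hydrogen-bond donor nor a hydrogen-bond acceptor stands level with acetamidomethyl. The side chain at this position can therefore be cut back to vinyl without a step beyond the scatter. No measurement bears on why the two groups stand level.

On these data alone, whether an amine, a carboxylic acid or a longer chain on this carbonyl carbon would also stay within the scatter remains open.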